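Swapping a chloropyridine for a methylphenyl on the amide

The source may hold more compounds than are shown below. What is called first, only, known or untested is meant among the compounds shown, and "the series" means these compounds.

Three measured compounds share one core and differ only in the aryl group attached to the amide carbonyl. Compound 1 `Cc1ccc(C(=O)NCN2CCC(c3cccc[n+]3[O-])CC2)cc1C` carries a 3,4-dimethylphenyl group, and in a functional assay on HEK293 cells for agonist activity at D(4) dopamine receptor (Homo sapiens), read by FLIPR (a higher number here means a larger maximal response, a lower number a smaller maximal response), compound 1 gives 65%. Compound 2 `N#Cc1cccc(C(=O)NCN2CCC(c3cccc[n+]3[O-])CC2)c1` carries a 3-cyanophenyl group, and compound 2 gives 69%. Compound 3 `O=C(NCN1CCC(c2cccc[n+]2[O-])CC1)c1cnccc1Cl` carries a 4-chloropyridin-3-yl group, and compound 3 gives 44%, the lowest of the three numbers. The steps between them show this plainly: a number 4 percentage points higher from compound 1 to compound 2 (within the scatter), whereas a number 21 percentage points lower from compound 1 to compound 3 (beyond the scatter) and a number 25 percentage points lower from compound 2 to compound 3 (beyond the scatter).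

Compound 4 `Cc1cccc(C(=O)NCN2CCC(c3cccc[n+]3[O-])CC2)c1` is the unmeasured member of the set. Its difference from compound 3 is 3-methylphenyl in place of 4-chloropyridin-3-yl on a carbonyl carbon. The two steps that bear on it are those leading into compound 3: each moved from a six-membered carbon-only ring to the ring with one hetero atom, and each lowered the response by a modest amount. The change to compound 4 runs the other way, with a carbon-only ring entering again. Compound 4 is therefore expected to climb back toward the level of compound 1 and compound 2, an expected step of a number 21 percentage points higher from compound 3 to compound 4 (beyond the scatter). The estimate for compound 4 in this assay is 65%, within a range from 50% to 78%.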

Compound 4, largest response reached (reported as efficacy), in percent of the reference or control that the assay uses: 77%
Estimate against measurement, compound 4: 12 percentage points below; the range from low to high includes it.
By their numbers in this assay, from the lowest: compound 3; then compounds 1, 2 and 4 (each within the scatter of the next, the first and the last beyond it).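

In this assay, 3-methylphenyl in place of 4-chloropyridin-3-yl on a carbonyl carbon gives a number 33 percentage points higher from compound 3 to compound 4 (beyond the scatter), a large step, whereas the two earlier steps into compound 3 were modest. The new compound also shows that the carbon-only rings are not all equal at this position: hydrogen in place of methyl on an aromatic carbon gives a number 12 percentage points higher from compound 1 to compound 4 (beyond the scatter), so a single methyl on the ring can shift the response by more than the usual scatter. Methyl in place of cyano on an aromatic carbon, by contrast, gives a number 8 percentage points higher from compound 2 to compound 4 (within the scatter), and no measurement shown here explains why any of these changes alters the maximal response as it does.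

The compounds shown leave open whether the ring nitrogen or the chlorine of the 4-chloropyridin-3-yl group goes with the lower response of compound 3, and a 4-chlorophenyl or a plain pyridin-3-yl group on the same carbonyl carbon would separate the two. On these data alone, it also remains open how a methoxy or a dimethylamino group would compare with the methyl of compound 4.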